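Working notes: from compound 2 to compound 4

The source may hold more compounds than are shown below. What is called first, only, known or untested is meant among the compounds shown, and "the series" means these compounds.

Values so far in a physicochemical assay for solubility, measured as kinetic solubility, at pH 2; on this read-out lower numbers stand for lower solubility and higher numbers for higher solubility
compound 1 `CC(C)C(/C=C1\NC(=O)NC1=O)c1ccc(-c2ccc3cccc(F)c3c2)[nH]c1=O` gives 7500 nM
compound 2 `CC(C)C(CC1C(=O)NC(=O)N1C)c1ccc(-c2ccc3cccc(F)c3c2)[nH]c1=O` gives 26600 nM
compound 3 `CC(C)[C@@H](c1ccc(-c2ccc3cccc(F)c3c2)[nH]c1=O)[C@@H]1OC(=O)NC1=O` gives 6900 nM

Compound 2 stands highest of the three on these numbers, and both other compounds lie beyond the scatter from it. The next entry is compound 4 `CC(C)C(c1ccc(-c2ccc3cccc(F)c3c2)[nH]c1=O)C1NC(=O)NC1=O`, which differs from compound 2 by 2,5-dioxoimidazolidin-4-yl in place of (3-methyl-2,5-dioxoimidazolidin-4-yl)methyl on a saturated chain carbon bound to an aromatic carbon and a saturated chain carbon on the same chain carbon. In words, 2,5-dioxoimidazolidin-4-yl replaces (3-methyl-2,5-dioxoimidazolidin-4-yl)methyl.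

Within the data shown here, only one measured step bears on this change, namely a 3.5-fold higher number from compound 1 to compound 2 (0.55 log units; beyond the scatter) in this assay and it is modest. It is not the same change, since compound 1 keeps a double bond that compound 4 does not have, so it serves only as a guide to size. Read in reverse, it points to a lower number on leaving compound 2. Compound 3 adds a second reference, as it also lacks the methyl and its value of 6900 nM sits under that of compound 2 as well.

The expected change is therefore a modest fall, estimated as a 2.7-fold lower number from compound 2 to compound 4 (0.42 log units; beyond the scatter) in this assay. For compound 4 the estimated value is 10000 nM with an expected range of 4500 nM to 22000 nM at this stage.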

Compound 4, solubility: 5800 nM
Estimate against measurement, compound 4: 1.7-fold (0.24 log units) above; the range from low to high includes it.
By their numbers in this assay, from the lowest: compounds 4, 3 and 1 (each within the scatter of the next); then compound 2.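

In this assay, among these compounds, 2,5-dioxoimidazolidin-4-yl in place of (3-methyl-2,5-dioxoimidazolidin-4-yl)methyl gives a 4.6-fold lower number from compound 2 to compound 4 (0.66 log units; beyond the scatter) on the saturated chain carbon, which is the only direct reading of this change so far. The same entering group, set against the group of compound 1, gives a 1.3-fold lower number from compound 1 to compound 4 (0.11 log units; within the scatter) and so does not separate these two groups on this read-out, while compound 2 now stands apart from compounds 1 and 4 by steps beyond the scatter. No measured information on the compounds accounts for these numbers.

The change from compound 2 to compound 4 removes the 3-methyl and the methyl link of the leaving group in a single step, so the compounds shown do not tell which of the two goes with the lower number. As far as these compounds go, it also remains open whether an amine or a carboxylic acid on the same saturated chain carbon would give a number close to those of compounds 1 and 4 or close to that of compound 2.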